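The source may report more compounds than this note shows. Statements on the series, on what has been measured and on what is new or still open speak of the compounds shown alone.

The measured compounds and their values:
- compound 1 `Cc1ncnc2c1c(I)cn2[C@@H]1O[C@H](CO)[C@@H](O)[C@H]1O`, which in an ADME assay on BJ cells (Homo sapiens), read by MTT assay, with a stated time of 72 h (a lower number here means a stronger inhibitor, a higher number a weaker inhibitor), gives > 100000 nM
- compound 2 `C#Cc1cn([C@@H]2O[C@H](CO)[C@@H](O)[C@H]2O)c2ncnc(C)c12`, which in this assay gives 50 nM
- compound 3 `C#Cc1cn([C@@H]2O[C@H](CO)[C@@H](O)[C@H]2O)c2ncnc(OC)c12`, which in this assay gives 98400 nM

The value for compound 1 is a limit of the assay, not a number (the limit of > 100000 nM in this assay, at which 1 of the 3 values shown sits). Compound 2 is the only one of the three with a low number. The change from compound 2 to compound 1 is iodo in place of ethynyl on an aromatic carbon, and it brought an at least 2000-fold higher number from compound 2 to compound 1 (3.30 log units; beyond the scatter). The cores of compound 2 and compound 3 differ by methoxy in place of methyl on an aromatic carbon, and that change brought a 2000-fold higher number from compound 2 to compound 3 (3.29 log units; beyond the scatter); compound 3 thus stands with the highest number among the two numbers that are not limits.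

Compound 4 `COc1ncnc2c1c(I)cn2[C@@H]1O[C@H](CO)[C@@H](O)[C@H]1O` has not yet been measured in this assay. Among the measured compounds shown here, it differs from compound 3 by iodo in place of ethynyl on an aromatic carbon, which is the same change as the one from compound 2 to compound 1, made at the same place, but now on the core of compound 3. Since the earlier step was an at least 2000-fold higher number from compound 2 to compound 1 (3.30 log units; beyond the scatter) and compound 3 already sits close to the limit of the assay, compound 4 is expected to give a step of a 3.0-fold higher number from compound 3 to compound 4 (0.48 log units; beyond the scatter), most likely reported only as a limit. Compound 4 is therefore estimated at 300000 nM, with a range from 100000 nM to 3000000 nM.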

Compound 4, half-maximal inhibitory concentration: 91000 nM
Beside the measured number, compound 4's estimate is 3.3-fold (0.52 log units) above it; measured number outside the range, below it.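

In this assay, the change to iodo in place of ethynyl did not carry from one core to the other: on the core of compound 3 it gave a 1.1-fold lower number from compound 3 to compound 4 (0.03 log units; within the scatter), and that step stands apart from the one on the core of compound 2: the same change on two cores in this assay, an at least 2000-fold higher number (3.30 log units; beyond the scatter) from compound 2 to compound 1 and a 1.1-fold lower number (0.03 log units; within the scatter) from compound 3 to compound 4, at least 2100-fold (3.33 log units) apart, beyond the scatter of two such steps The change to methoxy in place of methyl behaved the same way, giving an at least 1.0-fold lower number from compound 1 to compound 4 (0.04 log units; that floor lies within the scatter), which is only a floor, and it too stands apart from its earlier counterpart: the same change on two cores in this assay, a 2000-fold higher number (3.29 log units; beyond the scatter) from compound 2 to compound 3 and an at least 1.0-fold lower number (0.04 log units; that floor lies within the scatter) from compound 1 to compound 4, at least 2100-fold (3.33 log units) apart, beyond the scatter of two such steps Among these four compounds, only compound 2, which carries ethynyl and methyl together, has a low number, so each change on its own removes it and the second change then adds nothing that can be seen, but this does not show why, and the true size of any step involving compound 1 stays unknown, as its value is a limit and not a number: the limit of > 100000 nM in this assay, at which 1 of the 4 values shown sits.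

The compounds shown leave open whether the low number of compound 2 depends on these exact groups, or would survive an amine or a longer chain in place of methyl. They also leave open whether a nitrile or a longer alkyne chain in place of ethynyl would keep it.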